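Trimethoxyphenyl triazole thioethers: amide variant of compound 1

The compounds below may be only part of what the source reports. "The series", "measured", "known", "first", "only" and "open" are said of these compounds alone.

Measured so far:
- compound 1 `COc1cc(-c2nnc(SCC(=O)c3ccc(Cl)cc3)n2N)cc(OC)c1OC`: > 100000 nM
- compound 2 `COc1cc(-c2nnc(SCC(=O)c3ccc(C(F)(F)F)cc3)n2N)cc(OC)c1OC`: > 100000 nM
- compound 3 `COc1cc(-c2nnc(SCC(=O)Nc3ccccc3C)n2N)cc(OC)c1OC`: > 100000 nM

In a functional assay on PC-3 cells (Homo sapiens) for antiproliferative activity, read by MTT assay, with a stated time of 48 h (on this read-out lower numbers stand for stronger inhibition and higher numbers for weaker inhibition), compound 1 gives > 100000 nM, which is a limit of the assay and not a number. Compound 2 gives > 100000 nM in this assay, again only a limit. Compound 3 gives > 100000 nM in this assay, also a limit. All three values sit at the limit of > 100000 nM in this assay, at which 3 of the 3 values shown sit, so compound 1 stands nowhere in particular relative to the others: the three compounds cannot be ordered.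

The steps from compound 1 are a step that the two limits leave unreadable from compound 1 to compound 2 and a step that the two limits leave unreadable from compound 1 to compound 3, and between the other two a step that the two limits leave unreadable from compound 2 to compound 3; none of them has a readable size or direction.

Compound 4 `COc1cc(-c2nnc(SCC(=O)NCc3ccc(C)cc3)n2N)cc(OC)c1OC` differs from compound 1 as follows: (4-methylbenzyl)amino in place of 4-chlorophenyl on a carbonyl carbon. The closest measured comparison is the step from compound 1 to compound 3, which also places an arylamino group on the carbonyl carbon, and that step is unreadable. For the measured compounds named here, no measured step therefore supports an expected size or direction in this assay.

Compound 4 is expected to give 100000 nM in this assay, with a range of 30000 nM to 300000 nM, and most probably only a limit again. The expected step is a number no higher from compound 1 to compound 4 (the limit leaves the size open), with no readable direction.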

Compound 4, half-maximal inhibitory concentration: 92800 nM
The estimate for compound 4 lay 1.1-fold (0.03 log units) above the measured number; the measured number falls inside the stated range.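

In this assay compound 4 gives 92800 nM as a number and not a limit of the assay, so a substituent on this carbonyl carbon now has one readable value. The new steps are an at least 1.0-fold lower number from compound 1 to compound 4 (0.03 log units; that floor lies within the scatter) and an at least 1.0-fold lower number from compound 2 to compound 4 (0.03 log units; that floor lies within the scatter) and an at least 1.0-fold lower number from compound 3 to compound 4 (0.03 log units; that floor lies within the scatter) and each gives only a floor, so they do not show that (4-methylbenzyl)amino improves on the groups it replaces. The steps among compound 1, compound 2 and compound 3 cannot be read, and these compounds remain at a limit of the assay: the limit of > 100000 nM in this assay, at which 3 of the 4 values shown sit.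

The compounds shown leave open how far compound 4 really lies from the other three, and whether any difference belongs to the amide hydrogen, the benzyl chain or the 4-methyl group. They also leave open whether a 2-phenylethylamino group, a morpholine amide or a carboxylic acid on the same carbonyl carbon would give a value clearly apart from that of compound 4 in this assay.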